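Moving a Fluorine Around the Aniline Ring

The source may report more compounds than this note shows. Statements on the series, on what has been measured and on what is new or still open speak of the compounds shown alone.

Measured compounds in a functional assay on NCI-H1975 cells (Homo sapiens) for inhibition, read by MTT assay, with a stated time of 72 h; a lower number here means a stronger inhibitor, a higher number a weaker inhibitor:
compound 1 `O=C(CSc1nc(Nc2ccccc2)c2ccccc2n1)Nc1ccccc1Cl` gives 9610 nM
compound 2 `CCc1ccc(NC(=O)CSc2nc(Nc3ccccc3)c3ccccc3n2)cc1` gives 9910 nM
compound 3 `C=CC(=O)Nc1cccc(NC(=O)CSc2nc(Nc3ccccc3F)c3ccccc3n2)c1` gives 6580 nM

Compound 3 has the lowest of the three numbers, but its gaps to compound 1 and to compound 2 both lie within the usual scatter, so the three compounds cannot be told apart on these values.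

Compound 4 `C=CC(=O)Nc1cccc(NC(=O)CSc2nc(Nc3cccc(F)c3)c3ccccc3n2)c1` differs from compound 3 in one place: 3-fluorophenyl in place of 2-fluorophenyl on a nitrogen on an aromatic ring.

Among the measured compounds shown here, only one measured step exists here, a 1.0-fold higher number from compound 1 to compound 2 (0.01 log units; within the scatter), and it sits on the amide-type nitrogen, a different place from the one changed in compound 4; it stayed within the scatter. For the measured compounds named here, no measured pair shows what moving the fluorine on this nitrogen does. With nothing pointing either way, the expected step is none beyond the scatter, that is a 1.0-fold lower number from compound 3 to compound 4 (0.01 log units; within the scatter). Compound 4 is therefore estimated at 6500 nM, with a range from 2500 nM to 17000 nM.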

Compound 4, half-maximal inhibitory concentration: 2030 nM
The estimate for compound 4 lay 3.2-fold (0.51 log units) above the measured number; the whole stated range lies above it.
By their numbers in this assay, from the lowest: compound 4; then compounds 3, 1 and 2 (each within the scatter of the next).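

In this assay, the place of the fluorine on this ring turns out to matter: with the same atoms joined differently, 3-fluorophenyl in place of 2-fluorophenyl gives a 3.2-fold lower number from compound 3 to compound 4 (0.51 log units; beyond the scatter) in a step that counts as modest. This is the first step among the compounds shown to lie beyond the usual scatter, whereas the only earlier step, made on the amide-type nitrogen, stayed within it. No measurement at hand offers an explanation for this shift.

The compounds shown leave open how the number would respond to a chlorine atom or a methoxy group in place of the fluorine on this ring. They also leave open whether moving the fluorine gives a similar step when the amide-type nitrogen carries another group, such as the 2-chlorophenyl of compound 1.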